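The source may report more compounds than this note shows. Statements on the series, on what has been measured and on what is new or still open speak of the compounds shown alone.

Measured compounds in a physicochemical assay for solubility, with a stated time of 18 h, at pH 7.4; on this read-out higher numbers stand for higher solubility and lower numbers for lower solubility:

compound 1 `COc1cccc(CNCCCNc2ccnc3cc(-c4ccc(C(C)(C)C)cc4)ccc23)c1O`, giving 32000 nM
compound 2 `CN(C)c1cccc(Oc2ccc3c(NCCCNCc4ccco4)ccnc3c2)c1`, giving 14500 nM
compound 3 `Clc1ccc(Oc2ccc3c(NCCCNCc4ccco4)ccnc3c2)cc1`, giving 14500 nM

Compound 2 stands level with compound 3 in this assay; the two share the lowest numbers of the three, and compound 1 lies beyond the scatter above both. For the measured compounds named here, the one measured step, no change at the digits printed from compound 2 to compound 3 (within the scatter), changes the aryl group on the ether oxygen and leaves the amine end untouched.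

Compound 4 `COc1cccc(CNCCCNc2ccnc3cc(Oc4cccc(N(C)C)c4)ccc23)c1O` is not yet measured. It differs from compound 2 by 2-hydroxy-3-methoxyphenyl in place of furan-2-yl on a saturated chain carbon bound to an amine nitrogen; cut one bond further out, the change reads (furan-2-yl)methyl to 2-hydroxy-3-methoxybenzyl. Going by the values given here, no measured step changes this position, so the step from compound 2 to compound 3 does not bear on it directly. Compound 1 carries the same 2-hydroxy-3-methoxybenzyl group and gives 32000 nM, but its other end also differs, so only the two values can be compared. Compound 4 is therefore expected to give 20000 nM (range 8000 nM to 45000 nM), a step of a 1.4-fold higher number from compound 2 to compound 4 (0.14 log units; within the scatter) that is expected to stay within the scatter or rise only modestly.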

Compound 4, solubility: 14500 nM
Estimate against measurement, compound 4: 1.4-fold (0.14 log units) above, and the stated range covers the measured number.
By their numbers in this assay, from the lowest: compounds 2, 3 and 4 (each within the scatter of the next); then compound 1.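

In this assay the amine end now has a measured step of its own: (furan-2-yl)methyl to 2-hydroxy-3-methoxybenzyl gives no change at the digits printed from compound 2 to compound 4 (within the scatter), even though the entering group brings a hydrogen-bond donor that furan-2-yl lacks. With 2-hydroxy-3-methoxybenzyl held in common, the other end can be read as well, and 3-(dimethylamino)phenoxy in place of 4-(tert-butyl)phenyl on an aromatic carbon gives a 2.2-fold lower number from compound 1 to compound 4 (0.34 log units; beyond the scatter), a modest step and the only one shown that lies beyond the scatter. No measurement offered here accounts for either step.

As far as these compounds go, it remains open whether the amine-end step would read the same with the 4-chlorophenyl group of compound 3 on the ether oxygen. Also open, from the compounds shown here alone, is whether a carboxylic acid at the amine end, or a longer chain there, would shift the number.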